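Methoxy Added to an Anilide Where Every Value Is a Limit

This account rests on a few compounds, and the source may have more. Where it says the series, first, only, none or still open, it means among the compounds named here.

Compound 1 `COc1ccc(-c2nc3ccccc3s2)cc1NC(=O)c1cc([N+](=O)[O-])ccc1Cl`: in an ADME assay on HEK293 cells (Homo sapiens) for cytotoxicity, with a stated time of 72 h (on this read-out higher numbers stand for an effect only at larger amounts of compound and lower numbers for an effect already at smaller amounts), compound 1 gives > 25000 nM, a limit of the assay.
Compound 2 `O=C(Nc1cccc(-c2nc3ccccc3s2)c1)c1cc([N+](=O)[O-])ccc1Cl`: compound 2 gives > 27000 nM, again a limit.
Compound 3 `O=C(Nc1cccc(-c2nc3ccccc3o2)c1)c1cc([N+](=O)[O-])ccc1Cl`: compound 3 gives > 25000 nM, also a limit.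

Compound 2 therefore stands only at a limit in this assay, and the two further values shown are limits as well, so none of the three compounds can be placed above or below another. The two measured steps, a step that the two limits leave unreadable from compound 1 to compound 2 and a step that the two limits leave unreadable from compound 2 to compound 3, are both unreadable for the same reason: the limit of > 25000 nM in this assay, at which 2 of the 3 values shown sit, and the limit of > 27000 nM in this assay, at which 1 of the 3 values shown sits, are all that the measurements show.

Compound 4 `COc1ccc(NC(=O)c2cc([N+](=O)[O-])ccc2Cl)cc1-c1nc2ccccc2s1` differs from compound 2 by methoxy in place of hydrogen on an aromatic carbon. Compound 1 already carries a methoxy on its anilide ring and sits at a limit, so the nearest comparison offers no readable size for such a change. No step beyond the scatter can be expected from this evidence; the expected step that the limit leaves unreadable from compound 2 to compound 4 is none that the data can resolve. Compound 4 is accordingly estimated to give 30000 nM in this assay, within 15000 nM to 100000 nM, and most likely to be reported again as a limit.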

Compound 4, half-maximal effective concentration: > 25000 nM
Compound 4: a limit, no number; the forecaster's own chance of this, stated with the estimate: 90%; the middle value lies beyond the limit too.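

Among the compounds shown here, compound 2 and compound 4 both stand at limits in this assay, and no step between them can be read. The compounds shown leave open at what concentration any of the four would reach the half-maximal effect, and whether methoxy in place of hydrogen on an aromatic carbon changes that concentration at all.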